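Replacing trifluoromethyl with methylcarbamoyl: an expected half-life

A few compounds are considered here, and "the series" means these few. Any claim that something is new, unique, unknown or untested is made for them only; others in the source may bear on it.

Compounds measured so far:
Compound 1, `Cc1cc(CCC#N)cc(C)c1Oc1cc(Nc2ccc(C#N)cc2)c(N)cc1C(F)(F)F`: 0.928 h
Compound 2, `Cc1cc(/C=C/C#N)cc(C)c1Oc1cc(Nc2ccc(C#N)cc2)c(N)cc1C(F)(F)F`: 0.75 h
Compound 3, `Cc1cc(/C=C/C#N)cc(C)c1Oc1cc(Nc2ccc(C#N)cc2)c(N)cc1CO`: 0.503 h

These three compounds share a core and were tested in an in vitro ADME assay on microsomes from liver (Homo sapiens) for metabolic stability, tested at 1 uM; a lower number here means that the compound disappears faster, a higher number that the compound lasts longer. Compound 1 gives 0.928 h, which is the top of the three numbers, though the step of a 1.2-fold lower number from compound 1 to compound 2 (0.09 log units; within the scatter) lies within the scatter, and the gap from the value of compound 1 to that of compound 3 is also within the scatter. Between compound 2 and compound 3 the step of a 1.5-fold lower number from compound 2 to compound 3 (0.17 log units; within the scatter) likewise stays within the scatter.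

Compound 4, `CNC(=O)c1cc(N)c(Nc2ccc(C#N)cc2)cc1Oc1c(C)cc(CCC#N)cc1C`, has not yet been measured in this assay. It differs from compound 1 by methylcarbamoyl in place of trifluoromethyl on an aromatic carbon. The step that bears on this is a 1.5-fold lower number from compound 2 to compound 3 (0.17 log units; within the scatter), where the trifluoromethyl group was also exchanged, for hydroxymethyl, with no shift beyond the scatter. On this basis, for compound 4 the expected change is a 1.3-fold lower number from compound 1 to compound 4 (0.12 log units; within the scatter), a small downward move that remains within the scatter. The half-life of compound 4 in this assay is therefore estimated at 0.7 h, with a range from 0.35 h to 1.4 h.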

Compound 4, half-life: 0.928 h
The estimate for compound 4 lay 1.3-fold (0.12 log units) below the measured number; the measured number falls inside the stated range.
By their numbers in this assay, from the lowest: compounds 3, 2, 1 and 4 (each within the scatter of the next).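

At the aromatic carbon para to a (4-cyanophenyl)amino group, the exchange of trifluoromethyl for methylcarbamoyl gives, in this assay, no change at the digits printed from compound 1 to compound 4 (within the scatter) and so stays within the scatter. Until now this position had been varied only with hydroxymethyl, on a compound carrying 2-cyanoethenyl; compound 4 extends the picture to methylcarbamoyl and to a compound carrying 2-cyanoethyl, and it shows that a group with a hydrogen-bond donor and a hydrogen-bond acceptor can replace one with neither, without a half-life difference beyond the scatter. The information available offers no explanation for this outcome.

The compounds shown leave open whether methylcarbamoyl behaves the same way on the compound carrying 2-cyanoethenyl, since the exchange has been read only on the 2-cyanoethyl compound. They also leave open whether a carboxylic acid, an aminomethyl group or a dimethylcarbamoyl group at this position would move the half-life beyond the scatter, as neither exchange shown here does so.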